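Aryl swap on the shared core: compound 2 to compound 3

The compounds below may be only part of what the source reports. "The series", "measured", "known", "first", "only" and "open" are said of these compounds alone.

Among the measured compounds shown here, compound 2 `Cc1nn(-c2nc(-c3ccc(Cl)c(Cl)c3)c(SC(C)C)s2)c(C(=O)O)c1-c1ccccc1[N+](=O)[O-]` stands at the high end of the two numbers so far: in a functional assay on BJAB cells (Homo sapiens) for antiproliferative activity, with a stated time of 4 days (on this read-out higher numbers stand for an effect only at larger amounts of compound and lower numbers for an effect already at smaller amounts), compound 2 gives 4700 nM, while compound 1 `COc1cc(-c2c(C)nn(-c3nc(-c4ccc(Cl)c(Cl)c4)c(SC(C)C)s3)c2C(=O)O)cc(C(F)(F)F)c1` gives 1380 nM. For the measured compounds named here, the single measured step, a 3.4-fold higher number from compound 1 to compound 2 (0.53 log units; beyond the scatter), is therefore the one that bears on the present change. Compound 3 `COc1ccc(C)cc1-c1c(C)nn(-c2nc(-c3ccc(Cl)c(Cl)c3)c(SC(C)C)s2)c1C(=O)O` differs from compound 2 in one place: 2-methoxy-5-methylphenyl in place of 2-nitrophenyl on an aromatic carbon. The entering group, like that of compound 1, carries a methoxy group, and the 2-nitrophenyl that leaves is the group whose entry is recorded in a 3.4-fold higher number from compound 1 to compound 2 (0.53 log units; beyond the scatter) as a rise; a move back toward the number of compound 1, rather than a further rise, is therefore expected, on a scale of that step. For compound 3 the estimate in this assay is 1800 nM, with a range from 700 nM to 5000 nM. That corresponds to an expected 2.6-fold lower number from compound 2 to compound 3 (0.42 log units; beyond the scatter).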

Compound 3, half-maximal effective concentration: 9500 nM
Estimate against measurement, compound 3: 5.3-fold (0.72 log units) below; the measured number lies above the stated range.
By their numbers in this assay, from the lowest: compound 1; then compound 2; then compound 3.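

At this aromatic carbon, in this assay, 2-methoxy-5-methylphenyl in place of 2-nitrophenyl gives a 2.0-fold higher number from compound 2 to compound 3 (0.31 log units; beyond the scatter) and not a return toward compound 1, so carrying a methoxy group does not by itself set the aryl group of compound 1 apart. The gap between the two methoxy-bearing aryl groups is wider still, with a 6.9-fold higher number from compound 1 to compound 3 (0.84 log units; beyond the scatter) at this same carbon, which places them at opposite ends of the three numbers. Nothing available on these compounds accounts for the differences between the aryl groups.

These three aryl groups differ in more than one substituent, so the separate contributions of methoxy, methyl, nitro and trifluoromethyl cannot be told apart. On these data alone, how an unsubstituted phenyl, or a phenyl bearing an amine, would read at this carbon remains open.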